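A few compounds are considered here, and "the series" means these few. Any claim that something is new, unique, unknown or untested is made for them only; others in the source may bear on it.

Three compounds share one core. Compound 1, `Cc1n[nH]c2ccc(-c3nc4cnc(N5CCN(C)CC5)cn4c3Nc3ccccc3Cl)cc12`, and compound 2, `Cc1n[nH]c2ccc(-c3nc4cnc(N5CCN(C)CC5)cn4c3Nc3ccccc3)cc12`, were both prepared, yet in a functional assay on MV4-11 cells (Homo sapiens) for inhibition, with a stated time of 120 h (a higher number here means a weaker inhibitor, a lower number a stronger inhibitor), compound 1 returned "not determined" (no result reported) and in this assay compound 2 likewise returned "not determined" (no result reported), so neither contributes a number. Compound 3, `Cc1cc(Br)ccc1Nc1c(-c2ccc3[nH]nc(C)c3c2)nc2cnc(N3CCN(C)CC3)cn12`, is therefore the only member of the series with a measured result: in this assay compound 3 gives 10900 nM, which makes it a weak inhibitor and, among the numbers shown, the sole point of reference.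

Compound 4, `Cc1n[nH]c2ccc(-c3nc4cnc(N5CCN(C)CC5)cn4c3Nc3ccc(F)c(Cl)c3)cc12`, has not yet been measured. It differs from compound 3 in a single place, (3-chloro-4-fluorophenyl in place of 4-bromo-2-methylphenyl on a nitrogen on an aromatic ring), in words 3-chloro-4-fluorophenyl in place of 4-bromo-2-methylphenyl on a nitrogen on an aromatic ring. Going by the values given here, no step between two measured compounds exists to show what such an exchange does here. The account therefore expects no change beyond the scatter, the step from compound 3 to compound 4 in this assay being estimated at a 1.3-fold lower number from compound 3 to compound 4 (0.11 log units; within the scatter). On that basis compound 4 is expected in this assay to give about 8500 nM, within a range from 3000 nM to 25000 nM.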

Compound 4, half-maximal inhibitory concentration: 2850 nM
Estimate against measurement, compound 4: 3.0-fold (0.47 log units) above, outside the stated range (below it).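

In this assay the exchange gives a 3.8-fold lower number from compound 3 to compound 4 (0.58 log units; beyond the scatter) and so shows what compound 3 alone could not: the group on this nitrogen on an aromatic ring can shift the number beyond the scatter. The two groups have the same heavy-atom count and no hydrogen-bond donors or acceptors, so the step arises without any difference in these counts. No measurement shown here explains the step.

Going by these compounds, the steps to compound 1 and compound 2 cannot be read, and since the bromine, methyl, chlorine and fluorine all change together, the share of each in the step stays open. On these data alone, it also remains open how this position would respond to a methoxy or nitrile group on the phenyl ring, or to a saturated ring such as cyclohexyl in its place.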